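The source may report more compounds than this note shows. Statements on the series, on what has been measured and on what is new or still open speak of the compounds shown alone.

Measured compounds:
compound 1, `COc1ccccc1N1CCN(CCCNc2nc(C)cc(C)c2C(N)=O)CC1`: 10 nM
compound 2, `CN(C)C(=O)c1cccnc1NCCCN1CCN(c2ccccc2OCC2CC2)CC1`: 0.159 nM

Of the compounds shown here, two have been measured in a functional assay for antagonist activity at Alpha-1A adrenergic receptor (Oryctolagus cuniculus); on this read-out higher numbers stand for weaker binding and lower numbers for tighter binding. Compound 1, with the structure `COc1ccccc1N1CCN(CCCNc2nc(C)cc(C)c2C(N)=O)CC1`, gives 10 nM. Compound 2, with the structure `CN(C)C(=O)c1cccnc1NCCCN1CCN(c2ccccc2OCC2CC2)CC1`, gives 0.159 nM. On these two numbers compound 2 stands lowest, and its nearest neighbour, compound 1, lies beyond the usual scatter of this assay, so the two are clearly apart. Within the data shown here, no single-point step between measured compounds is known here.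

Compound 3, with the structure `CN(C)C(=O)c1cccnc1NCCCN1CCN(c2ccccc2C2CC2)CC1`, is not yet measured. It differs from compound 2 in one place: cyclopropyl in place of cyclopropylmethoxy on an aromatic carbon. The change sits on an aromatic carbon of a six-membered aromatic ring of carbon only, ortho to a large group.

Among the measured compounds shown here, with no measured step of this kind to lean on, the account expects a modest move toward a higher number in this assay, a step from compound 2 to compound 3 of a 3.1-fold higher number from compound 2 to compound 3 (0.50 log units; beyond the scatter), likely near the edge of the scatter. For compound 3 the estimate is 0.5 nM, within a range from 0.1 nM to 3 nM.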

Compound 3, dissociation constant: 0.631 nM
Beside the measured number, compound 3's estimate is 1.3-fold (0.10 log units) below it; the range from low to high includes it.
By their numbers in this assay, from the lowest: compound 2; then compound 3; then compound 1.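

In this assay, among these compounds, putting cyclopropyl in place of cyclopropylmethoxy on this aromatic carbon gives a 4.0-fold higher number from compound 2 to compound 3 (0.60 log units; beyond the scatter), the first measured step at this position, and it is modest but beyond the scatter. Among the compounds shown here, the three-membered ring stays in both compounds, while the entering group has fewer heavy atoms and no hydrogen-bond acceptor, so the loss of the oxygen and the methylene link costs only this modest step in this pair. No evidence here bears on why the step has this size. On these data alone, whether an ethoxy or an isopropyl group on this carbon would give a number nearer to that of compound 2 or of compound 3 remains open. Also open, as far as these compounds go, is whether a step of like size would hold with a pyrrolidine amide in place of the dimethyl amide.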